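A few compounds are considered here, and "the series" means these few. Any claim that something is new, unique, unknown or untested is made for them only; others in the source may bear on it.

Measured compounds:
Compound 1 `N#C/C(=C\N1CCN(C(=O)c2ccco2)C1=S)C(=O)Nc1ccc(Cl)cc1`: in a functional assay on LOX IMVI cells (Homo sapiens) for inhibition, read by sulforhodamine B assay, with a stated time of 48 h (on this read-out higher numbers stand for weaker inhibition of growth and lower numbers for stronger inhibition of growth), compound 1 gives 16700 nM.
Compound 2 `N#C/C(=C\N1CCN(C(=O)c2ccco2)C1=S)C(N)=O`: in this assay compound 2 gives 2500 nM.

Compound 2 stands at the lowest of the two numbers. Among the compounds with values here, its only neighbour is compound 1, and the step of a 6.7-fold lower number from compound 1 to compound 2 (0.82 log units; beyond the scatter) went with hydrogen in place of 4-chlorophenyl on an amide-type nitrogen.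

Compound 3 `N#C/C(=C\N1CCN(C(=O)c2ccco2)C1=S)C(=O)c1ccccc1` has not yet been measured in this assay. It differs from compound 2 by phenyl in place of amino on a carbonyl carbon. Within the data shown here, only the step from compound 1 to compound 2 bears on this change, and only loosely: there an aryl group left the amide-type nitrogen and the number fell by a modest, beyond-the-scatter amount; here an aryl group enters on the carbonyl carbon, and the amino group with its hydrogen-bond donor leaves. By that analogy the aryl-bearing compound is expected to give the higher number, though the place of the change is different and the step could also be small. The expected upward step is a 2.4-fold higher number from compound 2 to compound 3 (0.38 log units; beyond the scatter). The estimate for compound 3 is 6000 nM, with a range from 2000 nM to 20000 nM.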

Compound 3, concentration for 50% growth inhibition: 17900 nM
Beside the measured number, compound 3's estimate is 3.0-fold (0.47 log units) below it; the measured number falls inside the stated range.
By their numbers in this assay, from the lowest: compound 2; then compounds 1 and 3 (each within the scatter of the next).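

In this assay, the substituent on the carbonyl carbon matters on both sides of the amide: a 7.2-fold higher number from compound 2 to compound 3 (0.85 log units; beyond the scatter) went with phenyl in place of amino, so a change directly on this carbon moves the number about as far as the earlier change on the amide-type nitrogen did. a 1.1-fold higher number from compound 1 to compound 3 (0.03 log units; within the scatter) went with phenyl in place of (4-chlorophenyl)amino, so the two compounds carrying an aryl group stand together, whether or not an amide-type nitrogen links that group to the carbonyl, and compound 2, with the plain amino group, alone gives the lower number. No measurement here explains why the aryl-bearing compounds group together in this way.

The compounds shown cannot separate the entry of an aryl group from the loss of the amino group, as each compound has either the plain amino group or an aryl group at this place. A methylamino group or a methyl in place of the phenyl, giving a methyl ketone, would bear on that, and a carboxylic acid on the same carbon remains an open case.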